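A few compounds are considered here, and "the series" means these few. Any claim that something is new, unique, unknown or untested is made for them only; others in the source may bear on it.

Three compounds of the series have a number in an ADME assay for permeability, using PAMPA, with a stated time of 30 min, at pH 7.4; on this read-out higher numbers stand for higher permeability and lower numbers for lower permeability. Compound 1 `CC(C)Cc1ccc2c(NCCCNCc3ccco3)ccnc2c1` gives 23 10^-6 cm/s. Compound 2 `COc1ccc(F)cc1CNCCCNc1ccnc2cc(Oc3ccc(F)cc3)ccc12` gives 317 10^-6 cm/s, and compound 3 `COc1ccc(F)cc1CNCCCNc1ccnc2cc(Cc3ccc(F)cc3Cl)ccc12` gives 23 10^-6 cm/s. Within the data shown here, the only single-point step among the measured compounds is a 14-fold lower number from compound 2 to compound 3 (1.14 log units; beyond the scatter). Compound 1 sits level with compound 3 at the digits shown, the two together the lowest of the three numbers, and compound 2 stands well above both, beyond the scatter.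

Compound 4 `c1coc(CNCCCNc2ccnc3cc(CC4CCCCC4)ccc23)c1` is not yet measured. It differs from compound 1 in one place: cyclohexyl in place of isopropyl on a saturated chain carbon bound to an aromatic carbon. The change sits on a saturated chain carbon bound to an aromatic carbon of the shared core, whereas the measured step from compound 2 to compound 3 swaps the group on an aromatic carbon itself. Among the measured compounds shown here, no measured step tracks a change of the kind seen here, so the large step from compound 2 to compound 3 offers no direct guide, and the number for compound 1 is the only anchor. The expectation is therefore a step of about a 1.3-fold higher number from compound 1 to compound 4 (0.12 log units; within the scatter), that is, no change beyond the scatter. Compound 4 is accordingly estimated at 30 10^-6 cm/s, within a range of 12 10^-6 cm/s to 75 10^-6 cm/s.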

Compound 4, apparent permeability: 23 10^-6 cm/s
Beside the measured number, compound 4's estimate is 1.3-fold (0.12 log units) above it; the measured number falls inside the stated range.
By their numbers in this assay, from the lowest: compounds 1, 3 and 4 (each within the scatter of the next); then compound 2.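

In this assay, among these compounds, cyclohexyl in place of isopropyl on a saturated chain carbon bound to an aromatic carbon gives no change at the digits printed from compound 1 to compound 4 (within the scatter), the first reading of a change at this position. The same difference, read one bond further out as isobutyl to cyclohexylmethyl, takes the heavy atoms of the group from 3 to 6 carbon and adds a six-membered non-aromatic ring, with no shift in the number beyond the scatter, which contrasts with the swap on an aromatic carbon, where the series shows a 14-fold lower number from compound 2 to compound 3 (1.14 log units; beyond the scatter). Among the compounds shown here, the two steps differ in both place and group, so they show only that a large step is not seen for this carbon-only change, and nothing at hand gives a cause for the flat result.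

As far as these compounds go, both groups compared at this position are carbon only, so it remains open whether a primary amine or a carboxylic acid at the same place would leave the read-out as flat. From the compounds shown here alone, a longer chain ending in the cyclohexyl group is equally open, as one pair cannot say how far this position tolerates change.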